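Varying the group on the ring nitrogen of a sulfonamide series

The compounds below may be only part of what the source reports. "The series", "measured", "known", "first", "only" and "open" are said of these compounds alone.

Measured compounds:
- compound 1, `O=S(=O)(NC1CCN(S(=O)(=O)c2ccccc2)CC1)c1cc(S(=O)(=O)c2ccccc2)ccc1C(F)(F)F`: 210 nM
- compound 2, `O=C(O)c1ccc(N2CCC(NS(=O)(=O)c3cc(S(=O)(=O)c4ccccc4)ccc3C(F)(F)F)CC2)cc1`: 230 nM

The two measured compounds share a core and differ only in the group on an amine nitrogen in a ring. In an assay on U2OS cells for inhibition of secreted frizzled-related protein 1 (Homo sapiens), read by a luciferase reporter, with a stated time of 18 h (a lower number here means that less compound is needed, a higher number that more compound is needed for the effect), compound 1 gives 210 nM, and compound 2 gives 230 nM. For the measured compounds named here, compound 1 has the lowest of the two numbers, but its only neighbour, compound 2, lies within the scatter of it, so the two cannot be ordered. Going by the values given here, the one step that bears on the question is a 1.1-fold higher number from compound 1 to compound 2 (0.04 log units; within the scatter), where the 4-carboxyphenyl replaced the phenylsulfonyl without effect.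

Compound 3, `O=C([C@H]1CCNC1)N1CCC(NS(=O)(=O)c2cc(S(=O)(=O)c3ccccc3)ccc2C(F)(F)F)CC1`, is not yet measured. It differs from compound 1 in the same place: (pyrrolidin-3-yl)carbonyl in place of phenylsulfonyl on an amine nitrogen in a ring. Since a swap of the group at this position in the step from compound 1 to compound 2 changed nothing beyond the scatter, compound 3 is expected to come out close to compound 1, at about 300 nM, between 120 nM and 800 nM. This estimate means a step of a 1.4-fold higher number from compound 1 to compound 3 (0.15 log units; within the scatter), which is expected to stay within the scatter.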

Compound 3, half-maximal effective concentration: 700 nM
Compound 3: the middle estimate sits 2.3-fold (0.37 log units) below what was measured; the measured number falls inside the stated range.
By their numbers in this assay, from the lowest: compounds 1 and 2 (each within the scatter of the next); then compound 3.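

The group on this amine nitrogen in a ring is not free to vary without consequence: the swap to (pyrrolidin-3-yl)carbonyl gives a 3.3-fold higher number from compound 1 to compound 3 (0.52 log units; beyond the scatter) and a 3.0-fold higher number from compound 2 to compound 3 (0.48 log units; beyond the scatter), both beyond the scatter, whereas the step between the two earlier groups stayed within it. The 4-carboxyphenyl and phenylsulfonyl groups therefore remain indistinguishable, while compound 3 stands apart from both with a modestly higher number. Nothing measured here accounts for this difference.

The entering group differs from those it replaces in its carbonyl, its five-membered ring, its ring nitrogen and its defined stereocentre, and the three compounds do not show which of these features goes with the higher number. Going by these compounds, it remains open how a cyclopentylcarbonyl group, which lacks the ring nitrogen, or a simple acetyl group would compare with compound 3.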